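The compounds below may be only part of what the source reports. "The series", "measured", "known", "first", "only" and "open" are said of these compounds alone.

Measured in a functional assay on RAW264.7 cells (Mus musculus) for inhibition, read by Griess assay, with stated times of 1 h and 24 h; a higher number here means a weaker inhibitor, a lower number a stronger inhibitor:
- compound 1 `O=C1CC(c2ccccc2OCc2ccc(F)cc2)Oc2ccccc21`: 28200 nM
- compound 2 `CC(C)COc1ccccc1C1CC(=O)c2ccccc2O1`: 36700 nM
- compound 3 `CCCCCOc1ccccc1C1CC(=O)c2ccccc2O1`: 39200 nM

Compound 3, at 39200 nM, cannot be told apart from the other two compounds. Its values show a 1.1-fold higher number from compound 2 to compound 3 (0.03 log units; within the scatter) and a 1.4-fold higher number from compound 1 to compound 3 (0.14 log units; within the scatter). The next compound, compound 4 `O=C1CC(c2ccccc2OCc2cccc(F)c2)Oc2ccccc21`, carries 3-fluorophenyl in place of butyl on a saturated chain carbon bound to an oxygen on an aromatic ring.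

For the measured compounds named here, three measured steps bear on this change, all at the same place. Compound 1 carries 4-fluorophenyl there, and exchanging that ring for butyl gave a 1.4-fold higher number from compound 1 to compound 3 (0.14 log units; within the scatter). Exchanging it for isopropyl gave a 1.3-fold higher number from compound 1 to compound 2 (0.11 log units; within the scatter). So far, no change at this place has moved the reading in this assay beyond the scatter, so no step beyond the scatter is expected here either, in either direction. The estimated step is a 1.3-fold lower number from compound 3 to compound 4 (0.10 log units; within the scatter). For compound 4 the expected value is 31000 nM, with an estimated range of 16000 nM to 60000 nM.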

Compound 4, half-maximal inhibitory concentration: 15600 nM
Compound 4: the middle estimate sits 2.0-fold (0.30 log units) above what was measured; the measured number lies below the stated range.
By their numbers in this assay, from the lowest: compounds 4, 1, 2 and 3 (each within the scatter of the next, the first and the last beyond it).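

In this assay, this position gave its first steps beyond the scatter, both modest, when 3-fluorophenyl replaced butyl (a 2.5-fold lower number from compound 3 to compound 4 (0.40 log units; beyond the scatter)) or isopropyl (a 2.4-fold lower number from compound 2 to compound 4 (0.37 log units; beyond the scatter)). The ring alone does not account for this pattern, as compound 1 goes against it: its 4-fluorophenyl stays within the scatter of both chains, and exchanging it for 3-fluorophenyl also stays within the scatter (a 1.8-fold lower number from compound 1 to compound 4 (0.26 log units; within the scatter)), so the two fluorophenyl groups cannot be separated here. No measurement shown explains the difference between compound 4 and the two chain compounds.

The compounds shown leave open whether the fluorine matters at all, which a plain benzyl group would test, and whether a chlorine or methoxy group on the same ring would give a different reading. They also leave open how a chain ending in an amine or a carboxylic acid would read at this position.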